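A few compounds are considered here, and "the series" means these few. Any claim that something is new, unique, unknown or untested is made for them only; others in the source may bear on it.

Compound 3 `O=C(CSc1snnc1-c1ccc(F)cc1F)Nc1ccccc1[N+](=O)[O-]` carries the shared core. Among the compounds with values here, in an ADME assay on MT4 cells (Homo sapiens) for cytotoxicity (a higher number here means that more compound is tolerated, a lower number that less compound is tolerated), compound 3 gives 165000 nM, and that is the only plain number among the three measured compounds. Compound 1 `O=C(CSc1snnc1-c1ccccc1)Nc1ccccc1F` reaches only a limit in this assay, namely > 361000 nM. Compound 2 `O=C(CSc1snnc1-c1ccccc1)Nc1ccccc1Cl` likewise reaches only a limit in this assay, namely > 345000 nM. Within the data shown here, the single measured step, from compound 1 to compound 2, is a step that the two limits leave unreadable from compound 1 to compound 2, so it offers no size to lean on, and it concerns a different part of the molecule from the one changed here. Compound 4 `O=C(CSc1snnc1-c1ccccc1)Nc1ccccc1[N+](=O)[O-]` differs from compound 3 by phenyl in place of 2,4-difluorophenyl on an aromatic carbon. Among the measured compounds shown here, no measured step matches this change; the only hints are the limit of > 345000 nM in this assay, at which 1 of the 3 values shown sits, and (the limit of > 361000 nM in this assay, at which 1 of the 3 values shown sits), both from phenyl-bearing compounds, which show that such compounds can sit at a limit without telling how far they lie from compound 3. The resulting step in this assay is therefore expected to be modest, a 1.5-fold higher number from compound 3 to compound 4 (0.18 log units; within the scatter), leaning toward more compound being tolerated. Compound 4 is estimated at 250000 nM, with a range from 110000 nM to 600000 nM.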

Compound 4, half-maximal cytotoxic concentration: >= 246000 nM
Compound 4: only a limit was reported (the forecaster's own chance of this, stated with the estimate: 45%); the middle value lies beyond the limit too.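

In this assay, within the data shown here, replacing 2,4-difluorophenyl with phenyl on the carbon of the five-membered ring gives the first step that can be read at this position, an at least 1.4-fold higher number from compound 3 to compound 4 (0.17 log units; that floor lies within the scatter). Compound 4 reaches only a limit, so this step has a floor but no upper end, and the floor alone does not separate compound 4 from compound 3: the limit of >= 246000 nM in this assay, at which 1 of the 4 values shown sits. The steps that put nitro in place of chloro or fluoro, from compound 2 and from compound 1 to compound 4, cannot be read, so these three phenyl-bearing compounds cannot be ranked against one another.

The compounds shown leave open how much compound 4 is really tolerated, and so whether removing the two fluorines changes anything beyond the scatter of repeated measurements. They also leave open how this position responds to other groups, such as a phenyl carrying a single fluorine, an amine or a carboxylic acid, or a longer chain in place of the aromatic ring.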